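The compounds below may be only part of what the source reports. "The series", "measured", "known", "first", "only" and "open" are said of these compounds alone.

Going by the values given here, compound 1 `CCCCc1oc2ccccc2c1C(=O)c1ccc(OCC(=O)N2CCCCC2)cc1` is the weaker of the two compounds measured so far: in a functional assay on U-937 cells (Homo sapiens) for antiproliferative activity, read by MTT assay, with a stated time of 24 h (a higher number here means a weaker inhibitor, a lower number a stronger inhibitor), compound 1 gives 37100 nM, the highest of the two numbers, with compound 2 `CCCCc1oc2ccccc2c1C(=O)c1ccc(OCC(=O)Nc2ccccc2)cc1` nearest at 25900 nM. Among the compounds with values here, the only step between measured compounds, a 1.4-fold lower number from compound 1 to compound 2 (0.16 log units; within the scatter), comes from anilino in place of piperidin-1-yl on a carbonyl carbon, and it lies within the scatter. Compound 3 `CCCCc1oc2ccccc2c1C(=O)c1ccc(OCCCC(=O)N2CCCCC2)cc1` keeps the piperidine amide of compound 1 and instead lengthens the chain: 2-((piperidin-1-yl)carbonyl)ethyl in place of (piperidin-1-yl)carbonyl on a saturated chain carbon bound to an oxygen on an aromatic ring. Within the data shown here, no measured step touches the length of this chain, so nothing in the numbers at hand points in either direction, and the one step available changed a different part of the molecule. The expectation is therefore a step of about a 1.2-fold lower number from compound 1 to compound 3 (0.06 log units; within the scatter), not beyond the scatter. Compound 3 is estimated to give 32000 nM, with a range from 12000 nM to 85000 nM.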

Compound 3, half-maximal inhibitory concentration: 16600 nM
Compound 3: the middle estimate sits 1.9-fold (0.29 log units) above what was measured; low and high end bracket the measured number.
By their numbers in this assay, from the lowest: compounds 3, 2 and 1 (each within the scatter of the next, the first and the last beyond it).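

In this assay the length of the chain on the oxygen now shows an effect beyond the scatter: with the piperidine amide kept, 2-((piperidin-1-yl)carbonyl)ethyl in place of (piperidin-1-yl)carbonyl gives a 2.2-fold lower number from compound 1 to compound 3 (0.35 log units; beyond the scatter) as a modest step. Putting the same longer group in place of phenylcarbamoyl gives a 1.6-fold lower number from compound 2 to compound 3 (0.19 log units; within the scatter) and leaves these two compounds without an order, so the added chain length and the earlier anilino exchange cannot be ranked against each other on these numbers. Nothing available explains why the longer chain shifts the number.

Going by these compounds alone, with only two chain lengths, it remains open whether a still longer chain, such as 3-((piperidin-1-yl)carbonyl)propyl, would continue the shift or reverse it. Also open, as far as these compounds go, is how 2-(phenylcarbamoyl)ethyl, which joins the longer chain to the anilino group, or a carboxylic acid at the chain end would compare.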